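Compound 3: bromo in place of chloro

The source may hold more compounds than are shown below. What is called first, only, known or untested is meant among the compounds shown, and "the series" means these compounds.

Compound 1 (`O=C1/C(=C/c2ccncc2)CN(S(=O)(=O)c2ccc(F)cc2)C/C1=C\c1ccccc1F`) and compound 2 (`O=C1/C(=C/c2ccncc2)CN(S(=O)(=O)c2ccc(Cl)cc2)C/C1=C\c1ccccc1F`) differ in one place on a shared core. In a functional assay on SMMC-7721 cells (Homo sapiens) for cytotoxicity, read by MTT assay, with a stated time of 24 h (on this read-out lower numbers stand for stronger inhibition and higher numbers for weaker inhibition), compound 1 gives > 20000 nM, which is a limit of the assay and not a number. In this assay, for the measured compounds named here, compound 2 gives 9600 nM, the only actual number so far.

The next compound is compound 3 (`O=C1/C(=C/c2ccncc2)CN(S(=O)(=O)c2ccc(Br)cc2)C/C1=C\c1ccccc1F`), with the change bromo in place of chloro on an aromatic carbon, para to a large group.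

Going by the values given here, one measured step bears on this change: an at least 2.0-fold lower number from compound 1 to compound 2 (0.31 log units; beyond the scatter), with chloro in place of fluoro. On these data alone, its true size stays open, as it rests on (the limit of > 20000 nM in this assay, at which 1 of the 2 values shown sits). A single step does not make a trend, so only a small further move toward a lower number is expected in this assay, probably not beyond the scatter. The expected step is a 1.3-fold lower number from compound 2 to compound 3 (0.11 log units; within the scatter). For compound 3 the estimated value is 7500 nM, with an expected range of 3500 nM to 18000 nM.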

Compound 3, half-maximal inhibitory concentration: 12600 nM
The estimate for compound 3 lay 1.7-fold (0.23 log units) below the measured number; low and high end bracket the measured number.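

In this assay, bromo in place of chloro on this aromatic carbon, para to a large group, gives a 1.3-fold higher number from compound 2 to compound 3 (0.12 log units; within the scatter), so the two halogens cannot be told apart at this position on these numbers. The earlier step, an at least 2.0-fold lower number from compound 1 to compound 2 (0.31 log units; beyond the scatter), therefore does not extend into a run of lower numbers across the three halogens, and compound 3 goes against any such trend. Bromo in place of fluoro gives an at least 1.5-fold lower number from compound 1 to compound 3 (0.20 log units; that floor lies within the scatter), so this pair does not establish a difference beyond the scatter, and its true size cannot be read: the limit of > 20000 nM in this assay, at which 1 of the 3 values shown sits.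

The compounds shown vary only the halogen on the 4-halophenyl group, so it remains open whether a methoxy group, an amine or a nitrile at the same place would move the number beyond the scatter. Also open, on these data alone, is whether the near-identity of chloro and bromo holds when another part of the shared core is changed.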